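Furan-2-yl gives way to 2-methoxyphenyl

A few compounds are considered here, and "the series" means these few. Any claim that something is new, unique, unknown or untested is made for them only; others in the source may bear on it.

In a functional assay on THP-1 cells (Homo sapiens) for inhibition, read by sulforhodamine B assay, with a stated time of 48 h, tested at 50 uM (a higher number here means more inhibition of growth at the concentration tested, a lower number less inhibition of growth), compound 1 `COc1cc(/C=C/C(=O)/C=C/c2cccc3ccccc23)ccc1OCc1cn(CCCOc2cc(=O)oc3ccccc23)nn1` gives 71%, while compound 2 `COc1cc(/C=C/C(=O)/C=C/c2ccco2)ccc1OCc1cn(CCCOc2cc(=O)oc3ccccc23)nn1` gives 57%, the lower of the two numbers. Compound 3 `COc1ccccc1/C=C/C(=O)/C=C/c1ccc(OCc2cn(CCCOc3cc(=O)oc4ccccc34)nn2)c(OC)c1` departs from compound 2 in one place: 2-methoxyphenyl in place of furan-2-yl on a double-bonded chain carbon bound to a double-bonded chain carbon. Going by the values given here, the only measured step that bears on this change is a number 14 percentage points lower from compound 1 to compound 2 (beyond the scatter), with furan-2-yl in place of naphthalen-1-yl. Furan-2-yl now leaves again, so part of that loss is expected to return in this assay. The expected change is a modest rise, a number 11 percentage points higher from compound 2 to compound 3 (beyond the scatter). Compound 3 is estimated at 68%, within a range of 54% to 81%.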

Compound 3, percent growth inhibition at one concentration: 50%
The estimate for compound 3 lay 18 percentage points above the measured number, outside the stated range (below it).
By their numbers in this assay, from the lowest: compounds 3 and 2 (each within the scatter of the next); then compound 1.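

At this place, on a double-bonded chain carbon bound to a double-bonded chain carbon, 2-methoxyphenyl in place of furan-2-yl gives in this assay a number 7 percentage points lower from compound 2 to compound 3 (within the scatter) and so does not separate the two groups. Measured against naphthalen-1-yl, the same group gives a number 21 percentage points lower from compound 1 to compound 3 (beyond the scatter) and so shows that replacing furan-2-yl does not by itself restore the number: of the three groups, only naphthalen-1-yl stands clear of the other two. No evidence explains this result. On these data alone, whether phenyl, naphthalen-2-yl or a dimethylamino-bearing phenyl would match naphthalen-1-yl remains open.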